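The source may report more compounds than this note shows. Statements on the series, on what has been measured and on what is new or still open speak of the compounds shown alone.

Of the compounds shown here, three built on one shared core have been tested in a functional assay on SMMC-7721 cells (Homo sapiens) for antiproliferative activity, read by MTT assay, with a stated time of 72 h; on this read-out higher numbers stand for weaker inhibition and lower numbers for stronger inhibition. Compound 1 `CN(C(=O)C(C)(C)C)c1ccc2[nH]c(-c3n[nH]c4ccccc34)cc2n1` gives 22200 nM, compound 2 `COc1cccc(C(=O)N(C)c2ccc3[nH]c(-c4n[nH]c5ccccc45)cc3n2)c1` gives 22000 nM, and compound 3 `CN(C(=O)c1ccc([N+](=O)[O-])cc1)c1ccc2[nH]c(-c3n[nH]c4ccccc34)cc2n1` gives 18400 nM. Compound 3 sits alongside the other two: the steps of a 1.2-fold lower number from compound 1 to compound 3 (0.08 log units; within the scatter) and a 1.2-fold lower number from compound 2 to compound 3 (0.08 log units; within the scatter) both stay within the scatter, as does a 1.0-fold lower number from compound 1 to compound 2 (0.00 log units; within the scatter). Compound 4 `CN(C(=O)c1ccco1)c1ccc2[nH]c(-c3n[nH]c4ccccc34)cc2n1` differs from compound 3 in one place: furan-2-yl in place of 4-nitrophenyl on a carbonyl carbon. Each earlier exchange of the group on the carbonyl carbon, tert-butyl, 3-methoxyphenyl or 4-nitrophenyl, left this assay unchanged, so the step expected from this new exchange is a 1.1-fold higher number from compound 3 to compound 4 (0.04 log units; within the scatter). Compound 4 is therefore estimated at 20000 nM, with a range from 10000 nM to 40000 nM.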

Compound 4, half-maximal inhibitory concentration: 28200 nM
Compound 4: the middle estimate sits 1.4-fold (0.15 log units) below what was measured; the measured number falls inside the stated range.
By their numbers in this assay, from the lowest: compounds 3, 2, 1 and 4 (each within the scatter of the next).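

With furan-2-yl on the carbonyl carbon, a 1.5-fold higher number from compound 3 to compound 4 (0.19 log units; within the scatter) and a 1.3-fold higher number from compound 2 to compound 4 (0.11 log units; within the scatter) and a 1.3-fold higher number from compound 1 to compound 4 (0.10 log units; within the scatter) all stay within the scatter in this assay. A five-membered aromatic ring with a hetero atom therefore joins tert-butyl and the two substituted phenyl groups at this position, with no step beyond the scatter. No evidence is available on what lies behind these small steps. Going by these compounds, whether an amine or a carboxylic acid on this carbonyl carbon would give a step beyond the scatter remains open. So does the effect of changes elsewhere on the shared core.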